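This account rests on a few compounds, and the source may have more. Where it says the series, first, only, none or still open, it means among the compounds named here.

Three compounds have been measured in an assay on isolated protein for inhibition of Dihydrofolate reductase (Homo sapiens), read by spectrophotometry, using NADPH, with stated times of 5 s and 6 min, tested at 50 uM; on this read-out higher numbers stand for a stronger effect at the one concentration tested and lower numbers for a weaker effect:

- compound 1 `NC1=NC2(CCSCC2)N(OCCCOc2cccc(Cl)c2)C(N)=N1` gives 88.8%
- compound 2 `NC1=NC2(CCSCC2)N(OCCCOc2ccc(Br)cc2)C(N)=N1` gives "not determined" (no result reported)
- compound 3 `NC1=NC2(CCSCC2)N(OCCCOc2cccc(Cl)c2Cl)C(N)=N1` gives 89.8%

Compound 3 stands as the higher of the two numbers available, but the gap to compound 1 lies within the scatter, so the two cannot be ranked; compound 2 adds no number at all. Among the compounds with values here, the only step between measured compounds is a number 1 percentage points higher from compound 1 to compound 3 (within the scatter), and it is within the scatter.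

Compound 4 `NC1=NC2(CCSCC2)N(OCCCOc2cc(Cl)c(Cl)cc2Cl)C(N)=N1` has not yet been measured in this assay. It differs from compound 3 in one place: 2,4,5-trichlorophenyl in place of 2,3-dichlorophenyl on an oxygen on a saturated carbon. Within the data shown here, the one measured step that bears on this change, the addition of a chloro group on the aromatic ring from compound 1 to compound 3, moved the read-out by an amount within the scatter. On that basis, the step from compound 3 to compound 4 is expected to be a number 0.8 percentage points lower from compound 3 to compound 4 (within the scatter), that is, no change beyond the scatter. Compound 4 is therefore estimated to give 89%, with a range from 76% to 97%.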

Compound 4, a percentage reported as inhibition, at one concentration (the size of the read-out at that concentration, not a potency): 94.4%
Compound 4: middle estimate off by 5.4 percentage points, on the low side; the range from low to high includes it.
By their numbers in this assay, from the lowest: compounds 1, 3 and 4 (each within the scatter of the next).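

In this assay, putting 2,4,5-trichlorophenyl in place of 2,3-dichlorophenyl on an oxygen on a saturated carbon gives a number 4.6 percentage points higher from compound 3 to compound 4 (within the scatter), and putting it in place of 3-chlorophenyl gives a number 5.6 percentage points higher from compound 1 to compound 4 (within the scatter). The earlier compounds shown here with a number carried only one or two chlorines on the ring, so this result extends the picture to three, and the read-out at this position still shows no change beyond the scatter. Nothing available accounts for this result.

Each number is a read-out at one concentration, so the compounds shown leave open whether these chlorinated groups would give a stronger or weaker effect at any other concentration. They also leave open how the read-out would respond to an amine or a carboxylic acid on the aromatic ring, or to a longer chain carrying it.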